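From Propargyl to 2-Chlorobenzyl on the Shared Sulfur

The compounds below may be only part of what the source reports. "The series", "measured", "known", "first", "only" and "open" are said of these compounds alone.

Three compounds sharing one core were tested in a functional assay on MKN-45 cells (Homo sapiens) for cytotoxicity, read by MTT assay, with a stated time of 48 h; on this read-out lower numbers stand for stronger inhibition and higher numbers for weaker inhibition. Compound 1 `CCOC(=O)CSc1nnc(C)n1N1C(=O)c2ccccc2C1=O` carries an ethoxycarbonyl on the chain carbon bound to the sulfur, and in this assay compound 1 gives only a limit, > 200000 nM. Compound 2 `Cc1nnc(SCC(=O)c2ccc(Cl)cc2)n1N1C(=O)c2ccccc2C1=O` puts a (4-chlorophenyl)carbonyl at that place; in this assay compound 2 likewise gives only a limit, > 200000 nM. Compound 3 `C#CCSc1nnc(C)n1N1C(=O)c2ccccc2C1=O` carries an ethynyl there, and in this assay compound 3 also returns a limit, > 200000 nM. Accordingly the steps a step that the two limits leave unreadable from compound 1 to compound 2, a step that the two limits leave unreadable from compound 1 to compound 3 and a step that the two limits leave unreadable from compound 2 to compound 3 cannot be sized, a situation summed up by the limit of > 200000 nM in this assay, at which 3 of the 3 values shown sit. Compound 3 therefore stands nowhere in particular on the numbers: all that is known is that its potency lies beyond the reach of this assay, as does that of its two companions.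

Compound 4 `Cc1nnc(SCc2ccccc2Cl)n1N1C(=O)c2ccccc2C1=O` differs from compound 3 by 2-chlorophenyl in place of ethynyl on a saturated chain carbon bound to a sulfur. Within the data shown here, none of the measured steps can be read, so none gives a direction for this change; the only bearing they have is that every variation at this position so far has left the read-out at the limit. The account expects compound 4 to behave in the same way, with an estimated step of a number no higher from compound 3 to compound 4 (the limit leaves the size open). For compound 4 the estimated value in this assay is 200000 nM, within a range from 40000 nM to 1000000 nM.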

Compound 4, half-maximal inhibitory concentration: > 200000 nM
Compound 4: no number, only a limit; the forecaster's own chance of this, stated with the estimate: 75%; the middle value lies on the limit itself.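

Compound 4 gives only a limit in this assay, > 200000 nM. Its steps from compound 1, compound 2 and compound 3 therefore cannot be read, and the picture stays as it was: the limit of > 200000 nM in this assay, at which 4 of the 4 values shown sit. The compounds shown leave open how the four compare in potency, and whether any group on the saturated chain carbon bound to a sulfur would give a measurable value in this assay.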